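This account rests on a few compounds, and the source may have more. Where it says the series, first, only, none or still open, it means among the compounds named here.

Measured compounds:
- compound 1 `CCN(CC)CN1C(=O)/C(=N\c2nc3ccc(C)cc3s2)c2ccccc21`: 20400 nM
- compound 2 `CCN(CC)CN1C(=O)/C(=N\c2nc3ccc(C)cc3s2)c2c(Br)cccc21`: 16100 nM
- compound 3 `O=C1C(=O)N(CN(c2ccccc2)c2ccccc2)c2ccccc21`: 73000 nM

All three numbers come from an ADME assay on MCF-10A cells (Homo sapiens) for cytotoxicity, read by sulforhodamine B assay, with a stated time of 48 h; on this read-out lower numbers stand for stronger inhibition of growth and higher numbers for weaker inhibition of growth. Compound 3 gives the highest number of the three in this assay; its gap to compound 1 and to compound 2 lies beyond the scatter in each case, as noted above.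

Compounds 1 and 2 differ in one place, (bromo in place of hydrogen on an aromatic carbon). The step that this change made in this assay is a 1.3-fold lower number from compound 1 to compound 2 (0.10 log units; within the scatter).

Compound 4 `O=C1C(=O)N(CN(c2ccccc2)c2ccccc2)c2cccc(Br)c21` is not yet measured. It differs from compound 3 in the same way, (bromo in place of hydrogen on an aromatic carbon); the place of the change matches word for word, so this is the same change on a different core. How the core of compound 3 differs from the core of compound 1 is not broken down here.

Within the data shown here, because the only measured instance of the change, a 1.3-fold lower number from compound 1 to compound 2 (0.10 log units; within the scatter), lies within the scatter, the step from compound 3 to compound 4 is expected to be small as well, estimated as a 1.2-fold lower number from compound 3 to compound 4 (0.09 log units; within the scatter). Compound 4 is therefore expected near 60000 nM in this assay, with a likely range from 30000 nM to 120000 nM; this rests on one precedent only.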

Compound 4, concentration for 50% growth inhibition: 85800 nM
Compound 4: middle estimate off by 1.4-fold (0.16 log units), on the low side; the measured number falls inside the stated range.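

In this assay the new step is a 1.2-fold higher number from compound 3 to compound 4 (0.07 log units; within the scatter) and sits close to the earlier step, so the two cores give the same reading for this change: the same change on two cores in this assay, a 1.3-fold lower number (0.10 log units; within the scatter) from compound 1 to compound 2 and a 1.2-fold higher number (0.07 log units; within the scatter) from compound 3 to compound 4, 1.5-fold (0.17 log units) apart, within the scatter of two such steps.
Bromo in place of hydrogen on an aromatic carbon thus carries across these two cores without a step beyond the scatter on either, and the opposite directions of the two steps carry no weight.
This rests on two pairs in one assay with a single group, so it does not show that the change would stay this small on further cores, nor does it show that bromo has no effect on growth inhibition in general.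

As far as these compounds go, whether chloro, methoxy or a nitrile on the same aromatic carbon would also stay within the scatter remains open. Also open, from the compounds shown here alone, is how a carboxylic acid or a longer chain in place of the amine-bearing side chains would shift the number on either core.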